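The source may report more compounds than this note shows. Statements on the series, on what has been measured and on what is new or still open speak of the compounds shown alone.

Compound 1 `CNC(=O)c1cc(C(=O)N[C@H]2CC[C@H](O)CC2)c([C@@H](C)c2cccc(C)c2)o1` gives 3.3 in a physicochemical assay for lipophilicity; on this read-out higher numbers stand for higher lipophilicity and lower numbers for lower lipophilicity.
Compound 2 `CNC(=O)c1cc(C(=O)N[C@H]2[C@@H]3COC[C@@H]32)c([C@@H](C)c2ccccc2)o1` gives 4.1 in this assay.
Compound 3 `CNC(=O)c1cc(C(=O)N[C@H]2CC[C@H](O)CC2)c([C@@H](C)c2ccccc2Cl)o1` gives 3.1 in this assay.

Compound 2 stands highest of the three in this assay; its nearest neighbour is compound 1 and its furthest compound 3, both beyond the scatter. Compound 4 `CNC(=O)c1cc(C(=O)N[C@H]2CC[C@H](OC)CC2)c([C@@H](C)c2ccccc2)o1` differs from compound 2 in one place: a group of 8 heavy atoms (7 carbon, 1 oxygen; one six-membered non-aromatic ring of carbon only) in place of a group of 6 heavy atoms (5 carbon, 1 oxygen; one three-membered non-aromatic ring of carbon only, one five-membered non-aromatic ring with 1 hetero atom), on an amide-type nitrogen. For the measured compounds named here, the only step measured between single-change pairs, a number 0.20 log units lower from compound 1 to compound 3 (within the scatter), concerns the aryl group and not the amide nitrogen, so no measured step bears directly on this change. Compound 1 and compound 3 each differ from compound 2 in two places, so their values give only loose guidance. A modest downward step is therefore expected, a number 0.40 log units lower from compound 2 to compound 4 (beyond the scatter). Compound 4 is estimated at 3.7, with a range from 3.2 to 4.2.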

Compound 4, distribution coefficient: 4.1
The estimate for compound 4 lay 0.40 log units below the measured number; low and high end bracket the measured number.
By their numbers in this assay, from the lowest: compounds 3 and 1 (each within the scatter of the next); then compounds 2 and 4 (each within the scatter of the next).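

On the amide-type nitrogen, 4-methoxycyclohexyl in place of the group with the three-membered and five-membered rings gives no change at the digits printed from compound 2 to compound 4 (within the scatter) in this assay. This is the only step shown at this position, and it shows that the two groups, which differ in heavy-atom count and ring make-up, are not told apart by this read-out. Nothing measured here gives a reason for this result. Going by these compounds, whether a cyclohexyl group carrying an amine or a carboxylic acid would also stay within the scatter of compound 2 remains open. So does whether the same exchange gives the same result with the aryl groups of compound 1 and compound 3.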